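The source may hold more compounds than are shown below. What is called first, only, known or untested is meant among the compounds shown, and "the series" means these compounds.

Of the compounds shown here, three sharing one core have been tested. Compound 1 `CC(=O)Nc1ccc2oc(-c3cccc(F)c3)c(O)c(=O)c2c1` gives 36000 nM in an ADME assay on THP-1 cells (Homo sapiens) for cytotoxicity, read by flow cytometry and propidium iodide staining, with a stated time of 72 h; on this read-out higher numbers stand for weaker inhibition and lower numbers for stronger inhibition. Compound 2 `CC(=O)Nc1ccc2oc(-c3ccc(F)cc3)c(O)c(=O)c2c1` gives 26000 nM in this assay. The change between them is 4-fluorophenyl in place of 3-fluorophenyl on an aromatic carbon, and it made a step of a 1.4-fold lower number from compound 1 to compound 2 (0.14 log units; within the scatter). Compound 3 `COc1c(-c2cccc(F)c2)oc2ccc(NC(C)=O)cc2c1=O` differs from compound 1 by methyl in place of hydrogen on an oxygen on an aromatic ring, a step of an at least 3.4-fold higher number from compound 1 to compound 3 (0.54 log units; beyond the scatter). For compound 3 the result in this assay is only a limit, > 125000 nM, as the limit of > 125000 nM in this assay, at which 1 of the 3 values shown sits, shows. Compound 4 `COc1c(-c2ccc(F)cc2)oc2ccc(NC(C)=O)cc2c1=O` is not yet measured; it differs from compound 3 by 4-fluorophenyl in place of 3-fluorophenyl on an aromatic carbon, the same kind of change as from compound 1 to compound 2, though here the place is ortho to a methoxy group rather than to a hydroxy group. Because the earlier step of a 1.4-fold lower number from compound 1 to compound 2 (0.14 log units; within the scatter) lay within the scatter, compound 4 is expected to move little, a step that the limit leaves unreadable from compound 3 to compound 4. Compound 4 is therefore estimated at 150000 nM, between 60000 nM and 400000 nM.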

Compound 4, half-maximal inhibitory concentration: > 125000 nM
Compound 4 was reported as a limit; the forecaster's own chance of this, stated with the estimate: 70%; the middle value lies beyond the limit too.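

Putting methyl in place of hydrogen on the oxygen gives an at least 4.8-fold higher number from compound 2 to compound 4 (0.68 log units; beyond the scatter) in this assay, so the number rises with 4-fluorophenyl as it did with 3-fluorophenyl. The direction therefore carries from one core to the other, but the two sizes cannot be compared: the same change on two cores in this assay, an at least 3.4-fold higher number (0.54 log units; beyond the scatter) from compound 1 to compound 3 and an at least 4.8-fold higher number (0.68 log units; beyond the scatter) from compound 2 to compound 4; the limit leaves it open whether they differ. On these data alone, compound 4 gives > 125000 nM, which is a limit and not a number, and the step between compound 3 and compound 4 cannot be read, so whether the fluorine position matters once methyl sits on the oxygen remains unknown.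

The compounds shown leave open how a longer chain on that oxygen, such as ethyl or propyl, would read in this assay. They also leave open what an amine in place of the hydroxy group would do.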